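A few compounds are considered here, and "the series" means these few. Any claim that something is new, unique, unknown or untested is made for them only; others in the source may bear on it.

Series in a functional assay on Bel7402/5-FU cells (Homo sapiens) for antiproliferative activity, read by MTT assay, with a stated time of 72 h; on this read-out higher numbers stand for weaker inhibition and lower numbers for stronger inhibition:
- compound 1 `C=C1C(=O)O[C@H]2[C@H]1CC/C(COC(=O)Cn1cc(F)c(=O)[nH]c1=O)=C\CC[C@@]1(C)O[C@@H]21`: > 20000 nM (a limit of the assay, not a number)
- compound 2 `C=C1C(=O)O[C@H]2[C@H]1CC/C(COC(=O)Cn1cc(F)c(=O)n(Cc3ccccc3)c1=O)=C\CC[C@@]1(C)O[C@@H]21`: 4270 nM
- compound 3 `C=C1C(=O)O[C@H]2[C@H]1CC/C(COC(=O)Cn1cc(F)c(=O)n(Cc3ccccc3F)c1=O)=C\CC[C@@]1(C)O[C@@H]21`: 3830 nM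

Within the data shown here, compound 3, at 3830 nM, has one of the only two true numbers, and that number lies within the scatter of compound 2 at 4270 nM.

Compound 4 `C=C1C(=O)O[C@H]2[C@H]1CC/C(COC(=O)Cn1cc(F)c(=O)n(Cc3ccc(F)cc3F)c1=O)=C\CC[C@@]1(C)O[C@@H]21` replaces the 2-fluorobenzyl of compound 3 with 2,4-difluorobenzyl: fluoro in place of hydrogen on an aromatic carbon. The new fluoro takes the place of hydrogen on an aromatic carbon, meta to a fluoro group and para to a large group.

Among the measured compounds shown here, the closest precedent is the same kind of exchange in a 1.1-fold lower number from compound 2 to compound 3 (0.05 log units; within the scatter), which stays within the scatter. The larger steps of an at least 4.6-fold lower number from compound 1 to compound 2 (0.67 log units; beyond the scatter) and an at least 5.2-fold lower number from compound 1 to compound 3 (0.71 log units; beyond the scatter) come from substitution on an aromatic nitrogen, so they bear little on this change. No shift beyond the scatter is therefore expected in this assay. The expected step is a 1.1-fold lower number from compound 3 to compound 4 (0.04 log units; within the scatter).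

For compound 4 the estimated value is 3500 nM, with an expected range of 1800 nM to 7000 nM.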

Compound 4, half-maximal inhibitory concentration: 5010 nM
Compound 4: the middle estimate sits 1.4-fold (0.16 log units) below what was measured; the measured number falls inside the stated range.
By their numbers in this assay, from the lowest: compounds 3, 2 and 4 (each within the scatter of the next). At a limit, above all of these: compound 1.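

In this assay, a second fluoro on the aromatic carbon meta to a fluoro group and para to a large group gives a 1.3-fold higher number from compound 3 to compound 4 (0.12 log units; within the scatter). Taken as a whole, the exchange of phenyl for 2,4-difluorophenyl gives a 1.2-fold higher number from compound 2 to compound 4 (0.07 log units; within the scatter), so neither the single step nor the combined exchange separates compound 4 from the compounds with fewer fluoro groups. The substituted aromatic nitrogen still marks the one shift beyond the scatter, an at least 3.9-fold lower number from compound 1 to compound 4 (0.60 log units; beyond the scatter), but compound 1 stands at a limit of the assay, not a number, so this step is only a bound: the limit of > 20000 nM in this assay, at which 1 of the 4 values shown sits.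

Every substituent on the phenyl ring shown here is fluoro. From the compounds shown here alone, it remains open whether a methoxy group, an amine or a carboxylic acid at this place, or a longer chain in place of the benzyl, would move the number beyond the scatter.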